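A few compounds are considered here, and "the series" means these few. Any claim that something is new, unique, unknown or untested is made for them only; others in the source may bear on it.

In a functional assay on HL-60 cells (Homo sapiens) for cytotoxicity, read by ELISA, with a stated time of 2 days (a higher number here means a weaker inhibitor, a lower number a stronger inhibitor), compound 1 (`Oc1cccc(-c2cc(-c3ccccc3)nc(-c3ccccc3)c2)c1`) gives 13500 nM and compound 2 (`Oc1cccc(-c2cc(-c3ccccc3)nc(-c3cccs3)c2)c1`) gives 18900 nM as its value. These two values lie within the scatter of each other, so compound 2 stands level with compound 1. Compound 3 (`Oc1cccc(-c2cc(-c3ccccc3)nc(-c3ccsc3)c2)c1`) has thiophen-3-yl in place of thiophen-2-yl on an aromatic carbon next to the ring nitrogen (thiophen-3-yl in place of thiophen-2-yl on an aromatic carbon) and keeps the rest of compound 2 unchanged. Among the measured compounds shown here, the one measured step that bears on this change is a 1.4-fold higher number from compound 1 to compound 2 (0.15 log units; within the scatter) with thiophen-2-yl in place of phenyl, and it lies within the scatter. For the measured compounds named here, no measured compound yet carries thiophen-3-yl, so the data favour no direction, and no step beyond the scatter is expected in this assay here. The expected move is a 1.1-fold lower number from compound 2 to compound 3 (0.05 log units; within the scatter) and it is estimated to stay within the scatter. Compound 3 is expected at 17000 nM with a range of 8000 nM to 35000 nM estimated around it.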

Compound 3, half-maximal inhibitory concentration: 12000 nM
Beside the measured number, compound 3's estimate is 1.4-fold (0.15 log units) above it, and the stated range covers the measured number.
By their numbers in this assay, from the lowest: compounds 3, 1 and 2 (each within the scatter of the next).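

Among the compounds shown here, with compound 3, the attachment point of the thiophene ring at this position is tested for the first time: in this assay, thiophen-3-yl in place of thiophen-2-yl on the aromatic carbon next to the ring nitrogen gives a 1.6-fold lower number from compound 2 to compound 3 (0.20 log units; within the scatter). Thiophen-3-yl in place of phenyl gives a 1.1-fold lower number from compound 1 to compound 3 (0.05 log units; within the scatter), so phenyl, thiophen-2-yl and thiophen-3-yl all stand level here, and neither swapping phenyl for a thiophene ring nor changing that ring's attachment point separates these compounds. Nothing available offers a reason for this result.

From the compounds shown here alone, all three compounds are aromatic at this position and share the 3-hydroxyphenyl and remaining phenyl groups, so what those two groups contribute stays open. Also open, going by these compounds, is whether an amine, a carboxylic acid or a longer alkyl chain at this position would give a step beyond the scatter.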